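The source may hold more compounds than are shown below. What is called first, only, known or untested is meant among the compounds shown, and "the series" means these compounds.

Measured compounds:

Compound 1 `COc1cc(/C=C/C(=O)c2cccc(-n3cc(-c4ccccc4)[nH]c3=O)c2)ccc1O` gives 2020 nM in a functional assay on NCI-H23 cells (Homo sapiens) for inhibition; on this read-out lower numbers stand for stronger inhibition of growth and higher numbers for weaker inhibition of growth.
Compound 2 `O=C(/C=C/c1cccc(O)c1)c1cccc(-n2cc(-c3ccccc3)[nH]c2=O)c1` gives 3350 nM in this assay.
Compound 3 `COc1cc(/C=C/C(=O)c2cccc(-n3cc(-c4ccccc4)[nH]c3=O)c2)cc(OC)c1OC` gives 1430 nM in this assay.

The three numbers lie close together. Going by the values given here, compound 1 stands second highest of the three, with compound 3 nearest and compound 2 furthest, and both of those gaps are within the scatter; the one single-point step that is measured, a 1.7-fold higher number from compound 1 to compound 2 (0.22 log units; within the scatter), also stays within it and concerns only the aryl group on the double-bonded chain carbon, not the rest of the core.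

Compound 4 `COc1ccc(-c2cn(-c3cccc(C(=O)/C=C/c4ccc(O)c(OC)c4)c3)c(=O)[nH]2)cc1` differs from compound 1 by methoxy in place of hydrogen on an aromatic carbon, on an aromatic carbon of a six-membered aromatic ring of carbon only, para to a large group; seen one bond further out, the change reads phenyl to 4-methoxyphenyl. Among the compounds with values here, none of the measured compounds changes this ring, so no measured step bears on the change, and the only comparison available shows a small range of values across the set. A step within the scatter is therefore expected in this assay, with no clear direction. The estimate for compound 4 is 2000 nM, within 900 nM to 4500 nM, which is expected to mean a step of a 1.0-fold lower number from compound 1 to compound 4 (0.00 log units; within the scatter).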

Compound 4, concentration for 50% growth inhibition: 2850 nM
The estimate for compound 4 lay 1.4-fold (0.15 log units) below the measured number; low and high end bracket the measured number.
By their numbers in this assay, from the lowest: compounds 3, 1, 4 and 2 (each within the scatter of the next, the first and the last beyond it).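

Compound 4 is the first of these compounds to carry a change on the phenyl group of the shared core, as the one earlier step concerned only the aryl group on the double-bonded chain carbon. In this assay the change from phenyl to 4-methoxyphenyl gives a 1.4-fold higher number from compound 1 to compound 4 (0.15 log units; within the scatter) and so shows that methoxy in place of hydrogen, para to a large group, leaves the read-out within the usual scatter of this measurement. No supporting measurement is available to explain this result.

As far as these compounds go, it remains open whether a different group at this place, such as an amine, a carboxylic acid or a longer alkoxy chain, would also stay within the scatter. From the compounds shown here alone, it is equally open whether methoxy here would give a similar step alongside the aryl groups of compound 2 or compound 3.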